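The compounds below may be only part of what the source reports. "The series", "measured", "known", "first", "only" and "open" are said of these compounds alone.

Working notes on the series in a functional assay on DU-145 cells (Homo sapiens) for cytotoxicity, read by MTT assay; on this read-out higher numbers stand for weaker inhibition and lower numbers for stronger inhibition. Compound 1 `CC(C)=CC[C@@H](OC[C@H](C)O)C1=CC(=O)c2c(O)ccc(O)c2C1=O` gives 24500 nM, and compound 3 `CCCCC(O)CC(=O)O[C@H](CC=C(C)C)C1=CC(=O)c2c(O)ccc(O)c2C1=O` gives 45300 nM. Compound 2 `CC(C)=CC[C@@H](OC(=O)c1ccco1)C1=CC(=O)c2c(O)ccc(O)c2C1=O` has no number, only a limit of > 100000 nM. Compound 4 `COCCO[C@H](CC=C(C)C)C1=CC(=O)c2c(O)ccc(O)c2C1=O` is still unmeasured. It differs from compound 2 by 2-methoxyethyl in place of (furan-2-yl)carbonyl on an oxygen on a saturated carbon. For the measured compounds named here, two measured steps bear on this change, an at least 4.0-fold higher number from compound 1 to compound 2 (0.61 log units; beyond the scatter) and an at least 2.2-fold lower number from compound 2 to compound 3 (0.34 log units; beyond the scatter). Both are modest and beyond the scatter, and both leave the (furan-2-yl)carbonyl compound on the higher side, while a 1.8-fold higher number from compound 1 to compound 3 (0.27 log units; within the scatter) stays within the scatter. A lower number is therefore expected in this assay, with the expected step being an at least 2.8-fold lower number from compound 2 to compound 4 (0.45 log units; beyond the scatter). The estimate for compound 4 is 35000 nM, with an expected range of 12000 nM to 100000 nM.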

Compound 4, half-maximal inhibitory concentration: 43200 nM
Beside the measured number, compound 4's estimate is 1.2-fold (0.09 log units) below it; the range from low to high includes it.
By their numbers in this assay, from the lowest: compounds 1, 4 and 3 (each within the scatter of the next). At a limit, above all of these: compound 2.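

In this assay, 2-methoxyethyl carries no hydroxyl, yet a 1.8-fold higher number from compound 1 to compound 4 (0.25 log units; within the scatter) and a 1.0-fold lower number from compound 3 to compound 4 (0.02 log units; within the scatter) both stay within the scatter, so a hydroxyl on this oxygen's side chain is not needed to hold this level. The weak end of the series therefore goes with (furan-2-yl)carbonyl and not with the missing hydroxyl, as an at least 2.3-fold lower number from compound 2 to compound 4 (0.36 log units; beyond the scatter) shows. Compound 2 remains a limit, not a number: the limit of > 100000 nM in this assay, at which 1 of the 4 values shown sits.

Whether the furan ring alone accounts for this stays open, since compound 3 also has a carbonyl here. Also open, from the compounds shown here alone, is whether an amine or a carboxylic acid on this side chain would move the number beyond the scatter.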